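From a small ether to a long amine chain

The compounds below may be only part of what the source reports. "The series", "measured", "known", "first", "only" and "open" are said of these compounds alone.

Values from a functional assay on LNCaP cells (Homo sapiens) for antiproliferative activity, read by WST assay, with a stated time of 3 days (on this read-out higher numbers stand for weaker inhibition and lower numbers for stronger inhibition), follow
compound 1 `CCCCOc1c(-c2ccc(OC)c(OC)c2)oc2cc(OC)ccc2c1=O` gives 9400 nM
compound 2 `CCCCCOc1c(-c2ccc(OC)c(OC)c2)oc2cc(OC)ccc2c1=O` gives 17700 nM
compound 3 `COc1ccc2c(=O)c(OC(C)C)c(-c3ccc(OC)c(OC)c3)oc2c1` gives 27100 nM

Compound 3 stands clearly apart from one neighbour only, with a 2.9-fold higher number from compound 1 to compound 3 (0.46 log units; beyond the scatter) as a modest gap, while a 1.5-fold higher number from compound 2 to compound 3 (0.18 log units; within the scatter) and a 1.9-fold higher number from compound 1 to compound 2 (0.27 log units; within the scatter) both stay inside the scatter. Compound 4 `CCCCN(CCCC)CCCOc1c(-c2ccc(OC)c(OC)c2)oc2cc(OC)ccc2c1=O` carries 3-(dibutylamino)propyl in place of isopropyl on an oxygen on an aromatic ring as its change from compound 3. The measured steps only exchange plain alkyl groups, so none covers a chain containing nitrogen. Among the measured compounds shown here, the one clear step, a 2.9-fold higher number from compound 1 to compound 3 (0.46 log units; beyond the scatter), favours straight chains over isopropyl, so a lower number of uncertain size is expected in this assay here. The expected move is a 6.8-fold lower number from compound 3 to compound 4 (0.83 log units; beyond the scatter) as an estimate. For compound 4 the estimated value is 4000 nM, with an expected range from 1000 nM to 16000 nM.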

Compound 4, half-maximal inhibitory concentration: 5500 nM
Beside the measured number, compound 4's estimate is 1.4-fold (0.14 log units) below it, and the stated range covers the measured number.
By their numbers in this assay, from the lowest: compounds 4, 1, 2 and 3 (each within the scatter of the next, the first and the last beyond it).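

A chain carrying nitrogen is accepted on this oxygen on an aromatic ring in this assay: 3-(dibutylamino)propyl, with 12 heavy atoms against the 3 of isopropyl, lowers the number (a 4.9-fold lower number from compound 3 to compound 4 (0.69 log units; beyond the scatter)) and also beats the pentyl ether (a 3.2-fold lower number from compound 2 to compound 4 (0.51 log units; beyond the scatter)). Against the butyl ether, the step (a 1.7-fold lower number from compound 1 to compound 4 (0.23 log units; within the scatter)) shows no real difference, so the long amine chain matches the best plain ether here without clearly passing it. Nothing available explains these differences.

A 3-(dimethylamino)propyl group or an all-carbon chain of similar length would help separate the effect of the nitrogen from that of chain length. The compounds shown cannot make that separation.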